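A few compounds are considered here, and "the series" means these few. Any claim that something is new, unique, unknown or untested is made for them only; others in the source may bear on it.

Compound 1 `C=C(Br)C(=O)Nc1ccc(C(=O)/C=C/c2cc(OC)c(OC)c(OC)c2)cc1`: 280 nM
Compound 2 `COc1cc(/C=C/C(=O)c2ccc(N)cc2)cc(OC)c1`: 7500 nM

In a functional assay on MOLT-4 cells (Homo sapiens) for antiproliferative activity, with a stated time of 48 h (on this read-out higher numbers stand for weaker inhibition and lower numbers for stronger inhibition), compound 2 gives 7500 nM as the higher of the two numbers, and the gap down to compound 1 lies beyond the usual scatter. Compound 3 `COc1cc(/C=C/C(=O)c2ccc(N)cc2)cc(OC)c1OC` has not yet been measured. It differs from compound 2 in one place, with methoxy in place of hydrogen on an aromatic carbon, ortho to two methoxy groups and para to a large group methoxy in place of hydrogen on an aromatic carbon as the whole change.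

Going by the values given here, no measured pair shows this change alone. Compound 1 gives 280 nM and carries a methoxy group at that same place, but it also differs from compound 2 at the other end of the molecule, so it offers only a weak hint. A modest move towards stronger inhibition is therefore expected, and it may barely clear the scatter. The estimated step of a 2.5-fold lower number from compound 2 to compound 3 (0.40 log units; beyond the scatter) is small next to the gap between the two measured compounds. For compound 3 the expected value is 3000 nM within an estimated range from 700 nM to 10000 nM in this assay when it is tested.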

Compound 3, half-maximal inhibitory concentration: 5600 nM
Compound 3: middle estimate off by 1.9-fold (0.27 log units), on the low side; the range from low to high includes it.
By their numbers in this assay, from the lowest: compound 1; then compounds 3 and 2 (each within the scatter of the next).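

In this assay, methoxy in place of hydrogen on an aromatic carbon, ortho to two methoxy groups and para to a large group, gives a 1.3-fold lower number from compound 2 to compound 3 (0.13 log units; within the scatter), so this change alone cannot be told apart from the differences expected between repeated measurements. Going by these compounds alone, with the methoxy group present on both sides, the one change of hydrogen in place of (1-bromoethenyl)carbonyl on the nitrogen gives a 20-fold higher number from compound 1 to compound 3 (1.30 log units; beyond the scatter) in this assay. Nothing available here explains why either step has the size it has.

From the compounds shown here alone, it remains open whether a hydroxy group, an ethoxy group or a fluorine atom at this same position would also leave the number within the scatter, and whether the methoxy group would matter more in a compound that keeps the (1-bromoethenyl)carbonyl group. The role of the bromine is also unresolved, as a plain acetyl group on the nitrogen would be needed to show how much of the large step depends on that atom.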